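Swapping 2-fluorophenyl for 4-chlorophenyl at the assay limit

The source may hold more compounds than are shown below. What is called first, only, known or untested is meant among the compounds shown, and "the series" means these compounds.

Of the compounds shown here, three with a shared core have been tested in a functional assay on BGC-823 cells (Homo sapiens) for antiproliferative activity, read by MTT assay, with a stated time of 48 h; on this read-out lower numbers stand for stronger inhibition and higher numbers for weaker inhibition. Compound 1 (`S=c1oc(-c2ccc3c(c2)OCCO3)nn1CN1CCN(C(c2ccccc2)c2ccccc2)CC1`) gives > 50000 nM, which is a limit of the assay and not a number. Among the compounds with values here, compound 2 (`Cc1ccc(N2CCN(Cn3nc(-c4ccc5c(c4)OCCO5)oc3=S)CC2)c(C)c1`) gives 28300 nM, the only true number so far. Compound 3 (`Fc1ccccc1N1CCN(Cn2nc(-c3ccc4c(c3)OCCO4)oc2=S)CC1`) gives > 50000 nM, again a limit and not a number. Compound 3 therefore stands with compound 1, and the overall picture is the limit of > 50000 nM in this assay, at which 2 of the 3 values shown sit.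

Compound 4 (`S=c1oc(-c2ccc3c(c2)OCCO3)nn1CN1CCN(c2ccc(Cl)cc2)CC1`) carries 4-chlorophenyl in place of 2-fluorophenyl on an amine nitrogen in a ring. One measured step changes the same place, with 2-fluorophenyl in place of 2,4-dimethylphenyl: an at least 1.7-fold higher number from compound 2 to compound 3 (0.24 log units; that floor lies within the scatter). Within the data shown here, that is only a floor, so it sets no firm size for a change here, and no tested compound carries 4-chlorophenyl. No step beyond the scatter is therefore expected in this assay. Compound 2 at 28300 nM suggests that compound 4 will also be weak, if it gives a number at all. The expected change is an at least 1.1-fold lower number from compound 3 to compound 4 (0.07 log units; that floor lies within the scatter). For compound 4 the estimate is 42000 nM, with an expected range from 20000 nM to 80000 nM.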

Compound 4, half-maximal inhibitory concentration: > 50000 nM
Compound 4 gave a limit, no number (the forecaster's own chance of this, stated with the estimate: 55%); at least 1.1-fold (0.07 log units) between middle value and limit.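

Within the data shown here, with 4-chlorophenyl on the amine nitrogen in a ring, compound 4 also ends at a limit in this assay, so a second halogen-bearing phenyl group, with the halogen and its place on the ring both changed, gives no readable number, and compound 2 remains the only compound here with one. Among these compounds, the steps among the compounds at the limit cannot be read, including the change from 2-fluorophenyl to 4-chlorophenyl, while the one readable step, an at least 1.7-fold higher number from compound 2 to compound 4 (0.24 log units; that floor lies within the scatter), is only a floor within the usual scatter and so does not establish that 2,4-dimethylphenyl is better than 4-chlorophenyl at this position. What the series now shows is mainly how much of it lies out of the assay's reach: the limit of > 50000 nM in this assay, at which 3 of the 4 values shown sit.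

Going by these compounds, how far compound 1, compound 3 and compound 4 lie past that limit stays unknown, so any real differences among them remain hidden. Also open, on these data alone, is whether a single methyl group, a methoxy group or a pyridine ring at this place would give a number, and so whether the value of compound 2 is tied to its two methyl groups.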